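Two esters measured, one shorter ester awaiting assay

The compounds below may be only part of what the source reports. "The series", "measured", "known", "first", "only" and "open" are said of these compounds alone.

Compound 1 `CC(C)OC(=O)/C=C/c1ccc(C(C)C)cc1`: 18%
Compound 2 `CC(C)c1ccc(/C=C/C(=O)OCCOc2ccccc2)cc1`: 32%

Going by the values given here, in a functional assay on the whole organism for inhibition, with Brassica rapa subsp. chinensis as the target, with a stated time of 3 days, tested at 100 ppm (on this read-out lower numbers stand for less inhibition of growth and higher numbers for more inhibition of growth at the one concentration tested), compound 2 gives 32%, the highest of the two numbers so far; the nearest is compound 1, lower by an amount beyond the scatter. Compound 3 `CCOC(=O)/C=C/c1ccc(C(C)C)cc1` differs from compound 2 by hydrogen in place of phenoxy on a saturated chain carbon, two bonds along the chain from an oxygen next to a carbonyl group. Among the compounds with values here, no step between measured compounds is recorded. Compound 3 is expected to move downward in this assay, with an estimated step of a number 12 percentage points lower from compound 2 to compound 3 (beyond the scatter), because compound 1 gives 18% with a similar short ester. The estimate for compound 3 is 20%, ranging from 8% to 34%.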

Compound 3, percent growth inhibition at one concentration: 44%
Beside the measured number, compound 3's estimate is 24 percentage points below it; measured number outside the range, above it.
By their numbers in this assay, from the lowest: compound 1; then compound 2; then compound 3.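

Replacing phenoxy with hydrogen gives a number 12 percentage points higher from compound 2 to compound 3 (beyond the scatter) in this assay and so shows that phenoxy at this carbon is not needed for growth inhibition at the one concentration tested. Hydrogen in place of methyl on the saturated chain carbon bound to an oxygen next to a carbonyl group gives a number 26 percentage points higher from compound 1 to compound 3 (beyond the scatter) as well, so both single changes favour compound 3. No measurement given here bears on the reason for either step.

As far as these compounds go, whether a longer chain or an amine on the saturated chain carbon would hold or lose this inhibition remains open.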